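This account rests on a few compounds, and the source may have more. Where it says the series, first, only, none or still open, it means among the compounds named here.

Compound 1 `CCc1ccc(SCc2ccc(C(=O)Nc3ccccc3N)cc2)cc1`: 91.4%
Compound 2 `Nc1ccccc1NC(=O)c1ccc(CSc2ccc(Br)cc2)cc1`: 45.7%
Compound 3 `Nc1ccccc1NC(=O)c1ccc(CSCCc2ccccc2)cc1`: 84.1%

In a functional assay on A549 cells (Homo sapiens) for inhibition, read by CCK-8 assay, with a stated time of 72 h, tested at 8 uM (a higher number here means more inhibition of growth at the concentration tested, a lower number less inhibition of growth), compound 3 gives 84.1%, second of the three values. Going a number 7.3 percentage points lower from compound 1 to compound 3 (within the scatter) leaves it level with compound 1, and it stands well clear of compound 2.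

The next analogue is compound 4 `Nc1ccccc1NC(=O)c1ccc(CSc2ccc(F)cc2)cc1`, with 4-fluorophenyl in place of phenethyl on a sulfur.

The closest evidence is the same kind of swap read backwards, a number 38.4 percentage points higher from compound 2 to compound 3 (beyond the scatter). Going a number 45.7 percentage points lower from compound 1 to compound 2 (beyond the scatter) shows that an aryl group on the sulfur can also retain full effect, depending on its substituent. Fluoro itself is untested, so a partial loss is expected rather than the whole of that gap.

The expected step is a number 19.1 percentage points lower from compound 3 to compound 4 (beyond the scatter). For compound 4 the estimate is 65%, ranging from 42% to 88%.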

Compound 4, percent growth inhibition at one concentration: 44.5%
Beside the measured number, compound 4's estimate is 20.5 percentage points above it; measured number inside the range.
By their numbers in this assay, from the lowest: compounds 4 and 2 (each within the scatter of the next); then compounds 3 and 1 (each within the scatter of the next).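

In this assay, fluoro and bromo on the aromatic carbon read alike, with a number 1.2 percentage points lower from compound 2 to compound 4 (within the scatter). Set against ethyl there, the fluoro group gives a number 46.9 percentage points lower from compound 1 to compound 4 (beyond the scatter), and against phenethyl on the sulfur it gives a number 39.6 percentage points lower from compound 3 to compound 4 (beyond the scatter), so the low level belongs to both halogen-bearing aryl groups, not to bromo alone. Nothing available explains this split between the compounds. Still open, from the compounds shown here alone, is whether a methoxy or an amine on that aromatic carbon would side with compound 1 or with the halogens, and whether a longer chain on the sulfur would hold the level of compound 3.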